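Cyclopropyl Replaces Phenethyl on the Sulfur-Linked Chain

The compounds below may be only part of what the source reports. "The series", "measured", "known", "first", "only" and "open" are said of these compounds alone.

Three compounds sharing one core differ only in the group on a saturated chain carbon bound to a sulfur. In a functional assay on MGC-803 cells (Homo sapiens) for inhibition, read by MTT assay, with a stated time of 72 h (on this read-out lower numbers stand for stronger inhibition and higher numbers for weaker inhibition), compound 1 `Cc1cc(Nc2cc(-c3ccccc3)[nH]n2)n2nc(SCc3c(Cl)cccc3Cl)nc2n1` gives 5280 nM, compound 2 `Cc1cc(Nc2cc(-c3ccccc3)[nH]n2)n2nc(SCC(=O)c3ccccc3)nc2n1` gives 2580 nM, and compound 3 `Cc1cc(Nc2cc(-c3ccccc3)[nH]n2)n2nc(SCCCc3ccccc3)nc2n1` gives 6510 nM, the highest of the three numbers. The step of a 2.5-fold higher number from compound 2 to compound 3 (0.40 log units; beyond the scatter) reaches beyond the scatter, whereas a 1.2-fold higher number from compound 1 to compound 3 (0.09 log units; within the scatter) stays within it. Compound 4 `Cc1cc(Nc2cc(-c3ccccc3)[nH]n2)n2nc(SCC3CC3)nc2n1` carries cyclopropyl in place of phenethyl on a saturated chain carbon bound to a sulfur. Going by the values given here, no measured step exchanges a six-membered aromatic ring for a three-membered non-aromatic ring, so the only guide is that both swaps made at this place moved the number modestly at most. Compound 4 is therefore expected to land near compound 3. For compound 4 the step of a 1.1-fold higher number from compound 3 to compound 4 (0.03 log units; within the scatter) is expected to be small, and its value is estimated at 7000 nM, within a range from 2500 nM to 20000 nM.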

Compound 4, half-maximal inhibitory concentration: 16100 nM
Beside the measured number, compound 4's estimate is 2.3-fold (0.36 log units) below it; measured number inside the range.
By their numbers in this assay, from the lowest: compound 2; then compounds 1 and 3 (each within the scatter of the next); then compound 4.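

Going by these compounds alone, until now every group at this place carried a six-membered aromatic ring, and cyclopropyl, the smallest group here and the only one without such a ring, gives the weakest result in this assay with a 2.5-fold higher number from compound 3 to compound 4 (0.39 log units; beyond the scatter) and a 3.0-fold higher number from compound 1 to compound 4 (0.48 log units; beyond the scatter) and also a 6.2-fold higher number from compound 2 to compound 4 (0.80 log units; beyond the scatter) in the widest step. So this position does respond to the change, and the response is larger than any step among the earlier compounds.

As far as these compounds go, whether the ring or the size matters stays open, since a cyclohexyl or a plain hexyl chain would separate them. Nothing shown explains the rise in the number.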